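A few compounds are considered here, and "the series" means these few. Any claim that something is new, unique, unknown or untested is made for them only; others in the source may bear on it.

Measured compounds in an ADME assay on cells (Homo sapiens) for cytotoxicity, read by resazurin assay, with a stated time of 5 days; on this read-out lower numbers stand for higher toxicity in this test and higher numbers for lower toxicity in this test:

Compound 1 `O=S(=O)(Cc1nc(-c2ccnc(Cl)c2)c2sccc2n1)c1cccc(Cl)c1` gives 63000 nM.
Compound 2 `COc1ccc(-c2nc(CSc3cc(C)cc(C)c3)nc3ccsc23)cn1` gives > 50000 nM, which is a limit of this assay rather than a number.
Compound 3 `COc1ccc(-c2nc(S(=O)(=O)c3cccc(Cl)c3)nc3ccsc23)cn1` gives > 50000 nM, also a limit of this assay.

Compound 2 stands at the limit of this assay, and only a limit is known for it. For the measured compounds named here, two of the three values shown sit at that limit (the limit of > 50000 nM in this assay, at which 2 of the 3 values shown sit), and the single numbered value, that of compound 1, lies not far from it. Nothing in these three values separates compound 2 from the others.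

The compound to be measured is compound 4 `COc1ccc(-c2nc(CSc3cc(Cl)ccc3Cl)nc3ccsc23)cn1`. It keeps the core of compound 2 and changes only the group on the sulfur: 2,5-dichlorophenyl in place of 3,5-dimethylphenyl on a sulfur.

Going by the values given here, no step between measured compounds is available to set the size of this change. The values shown sit at or near the limit of this assay, and compound 1, carrying a different group on its sulfur, gives a number within reach of that limit. No step beyond the scatter is expected from compound 2 to compound 4 in this assay.

Compound 4 is therefore expected to give 60000 nM in this assay, within 20000 nM to 200000 nM, which corresponds to an expected step that the limit leaves unreadable from compound 2 to compound 4, and most likely this assay reports only a limit again for compound 4.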

Compound 4, half-maximal cytotoxic concentration: > 50000 nM
Compound 4 ended at the assay's limit; the forecaster's own chance of this, stated with the estimate: 65%; the middle value lies beyond the limit too.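

Compound 2 and compound 4 both end at a limit in this assay, so no step between them can be read: the limit of > 50000 nM in this assay, at which 3 of the 4 values shown sit.

Going by these compounds, whether 2,5-dichlorophenyl in place of 3,5-dimethylphenyl on a sulfur shifts the read-out at all stays open, as does how far past the limit either compound lies.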